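Adding fluoro to the methoxyphenyl ring of compound 3

This account rests on a few compounds, and the source may have more. Where it says the series, first, only, none or still open, it means among the compounds named here.

In a functional assay on HeLa cells (Homo sapiens) for inhibition, read by CCK-8 assay, with a stated time of 48 h (on this read-out lower numbers stand for stronger inhibition and higher numbers for weaker inhibition), compound 1 `COc1cc(-c2ccnc3cc(-c4ccc(C)cc4)nn23)cc(OC)c1OC` gives 21 nM, compound 2 `COc1cc(-c2ccnc3cc(-c4ccc(C(F)(F)F)cc4)nn23)cc(OC)c1OC` gives 1840 nM and compound 3 `COc1ccc(-c2cc3nccc(-c4cc(OC)c(OC)c(OC)c4)n3n2)cc1` gives 373 nM, the second highest of the three numbers. Compound 4 `COc1ccc(-c2cc3nccc(-c4cc(OC)c(OC)c(OC)c4)n3n2)cc1F`, not yet measured, has fluoro in place of hydrogen on an aromatic carbon, ortho to a methoxy group: fluoro in place of hydrogen on an aromatic carbon. The nearest evidence comes from swapping the group on that ring: an 88-fold higher number from compound 1 to compound 2 (1.94 log units; beyond the scatter), an 18-fold higher number from compound 1 to compound 3 (1.25 log units; beyond the scatter) and a 4.9-fold lower number from compound 2 to compound 3 (0.69 log units; beyond the scatter). These steps are modest to large, but none of them adds fluoro, so they only widen the range. The estimate is a 1.2-fold lower number from compound 3 to compound 4 (0.09 log units; within the scatter), which is expected to stay within the scatter. For compound 4 the expected value is 300 nM, with an estimated range of 90 nM to 1000 nM.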

Compound 4, half-maximal inhibitory concentration: 236 nM
Beside the measured number, compound 4's estimate is 1.3-fold (0.10 log units) above it; the measured number falls inside the stated range.
By their numbers in this assay, from the lowest: compound 1; then compounds 4 and 3 (each within the scatter of the next); then compound 2.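

In this assay fluoro in place of hydrogen, ortho to a methoxy group, gives a 1.6-fold lower number from compound 3 to compound 4 (0.20 log units; within the scatter) and so shows that this position accepts the added atom with no step beyond the scatter. The swaps of the whole group remain far larger, with a 7.8-fold lower number from compound 2 to compound 4 (0.89 log units; beyond the scatter) and an 11-fold higher number from compound 1 to compound 4 (1.05 log units; beyond the scatter) as the two steps that set the fluoro compound apart. Nothing available explains these steps. What the compounds shown leave open is how chloro or a hydroxyl group would read at this same position, and whether fluoro would give a similar result on the methyl-bearing ring of compound 1.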